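This account rests on a few compounds, and the source may have more. Where it says the series, first, only, none or still open, it means among the compounds named here.

Values in a functional assay on the whole organism (stomach) with Canis familiaris (Canis lupus familiaris) as the target; a lower number here means that less compound is needed, a higher number that more compound is needed for the effect:
- Compound 1 `COC(=O)CC/C=C\CC[C@H]1C(=O)C[C@@H](O)[C@@H]1/C=C/C[C@@](C)(O)/C=C/C1CCCC1`: 0.0003 mg/kg
- Compound 2 `COC(=O)CC/C=C\CC[C@H]1C(=O)C[C@@H](O)[C@@H]1/C=C/CC(C)(O)CCC1=CCCC1`: 0.0001 mg/kg

Compound 2 has the lower number of the two, 0.0001 mg/kg, so less of it is needed for the effect. Within the data shown here, the only measured step, a 3.0-fold lower number from compound 1 to compound 2 (0.48 log units; beyond the scatter), is modest but lies beyond the scatter.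

Compound 3 `COC(=O)CC/C=C\CC[C@H]1C(=O)C[C@@H](O)[C@@H]1/C=C/C[C@@](C)(O)/C=C/C1CC1` has not yet been measured. Its difference from compound 2 is as follows: 3-cyclopropyl-1-hydroxy-1-methylprop-2-en-1-yl in place of 3-(cyclopent-1-en-1-yl)-1-hydroxy-1-methylpropyl on a saturated chain carbon bound to a double-bonded chain carbon. The entering 3-cyclopropyl-1-hydroxy-1-methylprop-2-en-1-yl closely resembles the 3-cyclopentyl-1-hydroxy-1-methylprop-2-en-1-yl of compound 1, with cyclopropyl in place of cyclopentyl. Moving from compound 2 to compound 3 therefore largely reverses the measured step, which points to a higher number in this assay. Among the measured compounds shown here, no measured compound shows what cyclopropyl does in place of cyclopentyl, so this second part of the change remains open and the range must be wide. The expected change is a 5.0-fold higher number from compound 2 to compound 3 (0.70 log units; beyond the scatter), slightly larger than the measured step but of a similar order. For compound 3 the estimated value is 0.0005 mg/kg, with an expected range from 0.0001 mg/kg to 0.002 mg/kg.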

Compound 3, dose for half-maximal effect: 0.0001 mg/kg
For compound 3 the middle estimate is 5.0-fold (0.70 log units) above the measured one; the range from low to high includes it.
By their numbers in this assay, from the lowest: compounds 2 and 3 (each within the scatter of the next); then compound 1.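

In this assay, the exchange on the saturated chain carbon bound to a double-bonded chain carbon gives no change at the digits printed from compound 2 to compound 3 (within the scatter), so 3-cyclopropyl-1-hydroxy-1-methylprop-2-en-1-yl and 3-(cyclopent-1-en-1-yl)-1-hydroxy-1-methylpropyl cannot be told apart here, even though they differ in ring size and in where the double bond lies. The ring alone matters in the other comparison: cyclopropyl in place of cyclopentyl on a double-bonded chain carbon gives a 3.0-fold lower number from compound 1 to compound 3 (0.48 log units; beyond the scatter), a modest change that shows the prop-2-en-1-yl chain does not by itself fix the number, since compound 1 and compound 3 both carry it. No measurement at hand explains why either change has the size it has.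

As far as these compounds go, whether a cyclobutyl or a phenyl ring on the same double-bonded chain carbon would fall in line with cyclopropyl or with cyclopentyl remains open, so two ring sizes cannot yet be read as a trend. Also open, from the compounds shown here alone, is what an open-chain end such as isopropyl would do, and what the opposite arrangement at the defined stereocentre of compound 3 would do.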